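The compounds below may be only part of what the source reports. "The series", "measured", "known", "first", "only" and "open" are said of these compounds alone.

Of the compounds shown here, three built on one shared core have been measured in an assay on CHO cells for displacement of a labelled ligand from prostaglandin E2 receptor EP3 subtype (Homo sapiens), read by radioligand binding; a higher number here means a weaker inhibitor, a lower number a stronger inhibitor. Compound 1 `CC(C)C(c1nnc[nH]1)c1ccc(-c2ccc3cccc(F)c3c2)[nH]c1=O` gives 12 nM, compound 2 `CC(C)NC(=O)CC(c1ccc(-c2ccc3cccc(F)c3c2)[nH]c1=O)C(C)C` gives 5.8 nM, and compound 3 `CC(C)C(c1ccc(-c2ccc3cccc(F)c3c2)[nH]c1=O)N1CCCCC1=O` gives 6.4 nM. Among these numbers compound 2 holds the lowest; compound 3 stands nearest to it, within the scatter, while compound 1 stands furthest away, beyond the scatter.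

The next step leads from compound 2 to compound 4 `CC(C)C(c1ncco1)c1ccc(-c2ccc3cccc(F)c3c2)[nH]c1=O`, a change at the same side position: 1,3-oxazol-2-yl in place of (isopropylcarbamoyl)methyl on a saturated chain carbon bound to an aromatic carbon and a saturated chain carbon. The measured step that bears most directly on it is a 2.1-fold lower number from compound 1 to compound 2 (0.32 log units; beyond the scatter), where a five-membered aromatic ring, the 4H-1,2,4-triazol-3-yl group, gave way to the (isopropylcarbamoyl)methyl chain. The step of a 1.9-fold lower number from compound 1 to compound 3 (0.27 log units; within the scatter) ran in the same direction and was of comparable size, whereas a 1.1-fold higher number from compound 2 to compound 3 (0.04 log units; within the scatter) was negligible. Compound 4 returns to a five-membered aromatic ring, the 1,3-oxazol-2-yl group, so the change is read as roughly the reverse of the first step, giving a modest rise in the number rather than nothing beyond the scatter.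

The estimate for compound 4 is therefore 12 nM. For compound 4 the expected range runs from 4 nM to 35 nM. For compound 4 this means an expected step of a 2.1-fold higher number from compound 2 to compound 4 (0.32 log units; beyond the scatter).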

Compound 4, inhibition constant: 24 nM
For compound 4 the middle estimate is 2.0-fold (0.30 log units) below the measured one; measured number inside the range.
By their numbers in this assay, from the lowest: compounds 2, 3, 1 and 4 (each within the scatter of the next, the first and the last beyond it).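

In this assay the 1,3-oxazol-2-yl group on this saturated chain carbon separates compound 4 from both side groups that carry no aromatic ring (a 4.1-fold higher number from compound 2 to compound 4 (0.62 log units; beyond the scatter); a 3.8-fold higher number from compound 3 to compound 4 (0.57 log units; beyond the scatter)), whereas compound 1 stood clear only of compound 2 and lay within the scatter of compound 3. Set against the other five-membered aromatic ring, the 1,3-oxazol-2-yl group cannot be told apart from the 4H-1,2,4-triazol-3-yl group (a 2.0-fold higher number from compound 1 to compound 4 (0.30 log units; within the scatter)), so this position now shows a real spread between compound 4 and the two compounds with non-aromatic side groups, but none between its two aromatic rings. Nothing available here accounts for this difference.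

The compounds shown leave open how a phenyl ring, a carboxylic acid or an amine would read on the same saturated chain carbon. They also leave open whether a further five-membered aromatic ring, such as 1,3-thiazol-2-yl, would fall with compound 4 and compound 1, and so whether the aromatic ring itself goes with the higher numbers.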